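The compounds below may be only part of what the source reports. "The series", "measured", "known", "first", "only" and "open" are said of these compounds alone.

In a functional assay on Shh Light II cells (Mus musculus) for inhibition, read by a luciferase reporter (on this read-out higher numbers stand for weaker inhibition and lower numbers for stronger inhibition), compound 3 `COc1ccccc1NC(=O)N1CCC(c2nc(-c3ccc4ccccc4n3)no2)CC1` gives a value of (410 nM). That sits level with compound 2 `O=C(Nc1ccccc1C(F)(F)F)N1CCC(c2nc(-c3ccc4ccccc4n3)no2)CC1` (700 nM) and well under compound 1 `COc1ccccc1N(C)C(=O)N1CCC(c2nc(-c3ccc4ccccc4n3)no2)CC1` (3100 nM), which carries a methyl where the other two keep the amide hydrogen. The largest measured steps both start from compound 1: (a 7.6-fold lower number from compound 1 to compound 3 (0.88 log units; beyond the scatter)) and (a 4.4-fold lower number from compound 1 to compound 2 (0.65 log units; beyond the scatter)). Neither changes the aromatic group alone, so they say little here.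

Compound 4 `O=C(Nc1cccnc1Cl)N1CCC(c2nc(-c3ccc4ccccc4n3)no2)CC1` keeps the shared core and the amide hydrogen, with 2-chloropyridin-3-yl in place of 2-methoxyphenyl on an amide-type nitrogen. The closest guide is the swap of trifluoromethyl for methoxy on the aromatic ring (a 1.7-fold lower number from compound 2 to compound 3 (0.23 log units; within the scatter)), a change in this same group that stayed small. Within the data shown here, no measured compound has a hetero atom in this ring, however, so the guide is imperfect and the range must stay wide. No change beyond the scatter is expected, with at most a slight drift to a higher number (a 1.3-fold higher number from compound 3 to compound 4 (0.13 log units; within the scatter)). For compound 4 the estimated value is 550 nM, with an expected range from 180 nM to 1700 nM.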

Compound 4, half-maximal inhibitory concentration: 1600 nM
Compound 4: the middle estimate sits 2.9-fold (0.46 log units) below what was measured; the range from low to high includes it.
By their numbers in this assay, from the lowest: compounds 3 and 2 (each within the scatter of the next); then compounds 4 and 1 (each within the scatter of the next).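

The earlier change in this ring, trifluoromethyl to methoxy, stayed within the scatter, but the 2-chloropyridin-3-yl group moves the number beyond it in both comparisons (a 3.9-fold higher number from compound 3 to compound 4 (0.59 log units; beyond the scatter); a 2.3-fold higher number from compound 2 to compound 4 (0.36 log units; beyond the scatter)). This shows that the aromatic group on the amide-type nitrogen is not a freely interchangeable part: the read-out can respond to it even when the amide hydrogen is kept. Compound 4 also cannot be told apart from the methylated compound 1 (a 1.9-fold lower number from compound 1 to compound 4 (0.29 log units; within the scatter)), and no measurement shown here explains the shift.

The ring nitrogen and the chlorine enter together, so the compounds shown do not tell which of them accounts for the shift. A 2-chlorophenyl group or a pyridin-3-yl group without chlorine on this same nitrogen would separate the two.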